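The source may report more compounds than this note shows. Statements on the series, on what has been measured and on what is new or still open speak of the compounds shown alone.

Measured in an ADME assay on WI-38 cells (Homo sapiens) for antiproliferative activity, read by sulforhodamine B assay, with a stated time of 72 h; on this read-out higher numbers stand for weaker inhibition and lower numbers for stronger inhibition:
- compound 1 (`C=CCOC(=O)C1=C2C(=NC1=O)c1cccc3cccc2c13`) gives 20600 nM
- compound 2 (`C=CCOC(=O)C1=C2C(=NC1=O)c1cccc3c(SCCC)ccc2c13`) gives 33200 nM
- compound 3 (`CCCSC(=O)COC(=O)C1=C2C(=NC1=O)c1cccc3cccc2c13`) gives 25200 nM

The value of compound 2 lies within the usual scatter of both others, so the three read as level. Compound 4 (`CCCSc1ccc2c3c(cccc13)C1=NC(=O)C(C(=O)OCC)=C12`) carries methyl in place of vinyl on a saturated chain carbon bound to an oxygen next to a carbonyl group, turning allyloxycarbonyl into ethoxycarbonyl (methyl in place of vinyl on a saturated chain carbon bound to an oxygen next to a carbonyl group). For the measured compounds named here, the one measured change at this place, a 1.2-fold higher number from compound 1 to compound 3 (0.09 log units; within the scatter), put (propylsulfanyl)carbonyl in place of vinyl and stayed within the scatter. Adding propylsulfanyl, a 1.6-fold higher number from compound 1 to compound 2 (0.21 log units; within the scatter), did too. No step beyond the scatter is therefore expected in this assay. The estimated step is a 1.1-fold lower number from compound 2 to compound 4 (0.04 log units; within the scatter). For compound 4 the expected value is 30000 nM, with an estimated range from 17000 nM to 55000 nM.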

Compound 4, half-maximal inhibitory concentration: 9600 nM
Compound 4: the middle estimate sits 3.1-fold (0.49 log units) above what was measured, and the stated range ends above it.
By their numbers in this assay, from the lowest: compound 4; then compounds 1, 3 and 2 (each within the scatter of the next).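

In this assay, methyl in place of vinyl on a saturated chain carbon bound to an oxygen next to a carbonyl group gives a 3.5-fold lower number from compound 2 to compound 4 (0.54 log units; beyond the scatter), a step beyond the scatter from a change of a single carbon. For the compounds shown here, the earlier change at this place stayed within the scatter, so this is the first sign that the number responds to this chain. Nothing available explains the step. Going by these compounds, whether the same change lowers the number without propylsulfanyl stays open, as does the effect of a longer chain such as butyl, or of a carboxylic acid, at this place.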